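Oxolan-3-yl to methyl on the shared core

The compounds below may be only part of what the source reports. "The series", "measured", "known", "first", "only" and "open" are said of these compounds alone.

In an ADME assay on microsomes from liver (Rattus norvegicus) for metabolic stability, with a stated time of 60 min, tested at 1 uM (on this read-out higher numbers stand for a more stable compound and lower numbers for a less stable compound), compound 1 (`COc1cc(-c2cnn3cc(OC)c(-c4cc(C)no4)nc23)ccn1`) gives 62%. Among the compounds with values here, compound 2 (`COc1cc(-c2cnn3cc(OC)c(C4CCOC4)nc23)ccn1`) gives 34%, the lower of the two numbers so far, with compound 1 as its only neighbour and beyond the scatter from it.

Compound 3 (`COc1cc(-c2cnn3cc(OC)c(C)nc23)ccn1`) carries methyl in place of oxolan-3-yl on an aromatic carbon, next to the ring nitrogen and ortho to a methoxy group: methyl in place of oxolan-3-yl on an aromatic carbon.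

Within the data shown here, only one measured step bears on this change, and it sits at the same place: a number 28 percentage points lower from compound 1 to compound 2 (beyond the scatter), a modest step beyond the scatter, with oxolan-3-yl replacing 3-methyl-1,2-oxazol-5-yl. It shows that the group at this place can move the read-out. Among the measured compounds shown here, no measured compound has methyl here, so the direction is a weak call from a single step. With compound 2 at the low end at 34%, an upward move is more likely than a downward one. The expected step is a number 14 percentage points higher from compound 2 to compound 3 (beyond the scatter), similar to or smaller than the measured one. In this assay the estimate for compound 3 is 48%, with an expected range of 30% to 68%.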

Compound 3, percent of the compound remaining: 13%
The estimate for compound 3 lay 35 percentage points above the measured number; measured number below the stated range.
By their numbers in this assay, from the lowest: compound 3; then compound 2; then compound 1.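

Methyl in place of oxolan-3-yl gives a number 21 percentage points lower from compound 2 to compound 3 (beyond the scatter) in this assay, so the low number of compound 2 does not mark the bottom of the range at this aromatic carbon. Methyl in place of 3-methyl-1,2-oxazol-5-yl gives a number 49 percentage points lower from compound 1 to compound 3 (beyond the scatter) and is the largest step at this place so far; the three groups now stand in a clear order, with 3-methyl-1,2-oxazol-5-yl highest, oxolan-3-yl next and methyl lowest, and both compounds with a ring here stand above the one without, an observation that rests on three compounds only. The measurements at hand give no explanation for this order.

Still open, from the compounds shown here alone, is whether any ring at this aromatic carbon is enough to raise the number, or whether an amine, a carboxylic acid or a longer alkyl chain would also stand above methyl. The methoxy group and the rest of the shared core are the same in all three compounds, so their share in the read-out cannot be told from this set.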